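Phenyl in Place of Thiophen-3-yl: Expecting Compound 4

The source may hold more compounds than are shown below. What is called first, only, known or untested is meant among the compounds shown, and "the series" means these compounds.

Measured compounds:
compound 1, `Oc1ccc(-c2cc(-c3ccccc3)nc(-c3ccccc3Cl)c2)cc1`: 13.6%
compound 2, `Oc1cccc(-c2cc(-c3ccco3)nc(-c3ccccc3Cl)c2)c1`: 0%
compound 3, `Oc1cccc(-c2cc(-c3ccsc3)nc(-c3ccccc3Cl)c2)c1`: 0%

In an assay on isolated protein for inhibition of DNA topoisomerase 1 (Homo sapiens), with a stated time of 30 min, tested at 100 uM (on this read-out lower numbers stand for a weaker effect and higher numbers for a stronger effect at the one concentration tested), compound 3 gives 0%, level with compound 2 within the scatter, and the two stand together at the bottom of the three numbers; compound 1 lies higher, beyond the scatter. Among the compounds with values here, the only measured step, no change at the digits printed from compound 2 to compound 3 (within the scatter), shows that exchanging one five-membered ring for another leaves this assay unchanged. Compound 4, `Oc1cccc(-c2cc(-c3ccccc3)nc(-c3ccccc3Cl)c2)c1`, arises from compound 3 by phenyl in place of thiophen-3-yl on an aromatic carbon. Within the data shown here, no measured step covers a phenyl entering in place of a heteroaryl; compound 1 carries a phenyl but differs elsewhere too. Compound 4 is therefore expected to stay near the floor, with a number 5 percentage points higher from compound 3 to compound 4 (within the scatter), and its inhibition is estimated at 5%, within 0% to 15%.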

Compound 4, a percentage reported as inhibition, at one concentration (the size of the read-out at that concentration, not a potency): 3.2%
The estimate for compound 4 lay 1.8 percentage points above the measured number; measured number inside the range.
By their numbers in this assay, from the lowest: compounds 2, 3 and 4 (each within the scatter of the next); then compound 1.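

In this assay, a six-membered phenyl on this aromatic carbon next to the ring nitrogen reads the same as either five-membered ring, with a number 3.2 percentage points higher from compound 3 to compound 4 (within the scatter) and a number 3.2 percentage points higher from compound 2 to compound 4 (within the scatter). Within the data shown here, the hydroxyl position matters more here, with a number 10.4 percentage points lower from compound 1 to compound 4 (beyond the scatter) on 3-hydroxyphenyl in place of 4-hydroxyphenyl, the only one of these steps beyond the scatter. Nothing available explains either result. Open, on these data alone, is whether 4-hydroxyphenyl keeps its number with thiophen-3-yl or furan-2-yl at this position, and what an amine or a carboxylic acid on the phenyl would do.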